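The source may hold more compounds than are shown below. What is called first, only, known or untested is meant among the compounds shown, and "the series" means these compounds.

Compound 1 `COc1ccc(/C=C/C(=O)O)c(OC(=O)c2nc(C)c(C)nc2C)c1`: 115000 nM
Compound 2 `CCOC(=O)/C=C/c1ccc(OC)cc1OC(=O)c1nc(C)c(C)nc1C`: 138000 nM

In a functional assay on EA.hy 926 cells (Homo sapiens) for cytotoxicity, read by MTT assay, with stated times of 24 h and 12 h (on this read-out higher numbers stand for an effect only at larger amounts of compound and lower numbers for an effect already at smaller amounts), compound 1 gives 115000 nM and compound 2 gives 138000 nM, so the two stand within the scatter of each other. The account now moves to compound 3 `CCOC(=O)/C=C/c1ccccc1OC(=O)c1nc(C)c(C)nc1C`, which differs from compound 2 at a single place, with hydrogen in place of methoxy on an aromatic carbon. For the measured compounds named here, the one measured step, a 1.2-fold higher number from compound 1 to compound 2 (0.08 log units; within the scatter), lies elsewhere on the molecule, so it bears on this change only indirectly. Going by the values given here, no measured pair tests the loss of the methoxy. With so little evidence, no step beyond the scatter is expected in this assay. The expected step is a 1.1-fold lower number from compound 2 to compound 3 (0.03 log units; within the scatter). Compound 3 is estimated at 130000 nM, with an expected range from 60000 nM to 280000 nM.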

Compound 3, half-maximal effective concentration: 108000 nM
The estimate for compound 3 lay 1.2-fold (0.08 log units) above the measured number; the measured number falls inside the stated range.
By their numbers in this assay, from the lowest: compounds 3, 1 and 2 (each within the scatter of the next).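

In this assay, hydrogen in place of methoxy on the aromatic carbon para to a 2-(ethoxycarbonyl)ethenyl group gives a 1.3-fold lower number from compound 2 to compound 3 (0.11 log units; within the scatter), the first measured test of this position. On this read-out compound 2 and compound 3 cannot be told apart, so the methoxy at this place carries no measurable weight in this pair. Nothing measured here speaks to the reason for this outcome.

From the compounds shown here alone, whether another group at this position, such as an amine, a hydroxyl or a longer alkoxy chain, would move the number beyond the scatter stays open. Also open, going by these compounds, is whether the same change would read the same way on the free carboxylic acid of compound 1 as it does on the ethyl ester.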